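A Phenyl for a Methyl on the Ring Amine Nitrogen

The compounds below may be only part of what the source reports. "The series", "measured", "known", "first", "only" and "open" are said of these compounds alone.

Of the compounds shown here, three have so far been tested in an ADME assay on MT4 cells (Homo sapiens) for cytotoxicity, read by MTT assay, with a stated time of 96 h; on this read-out higher numbers stand for lower toxicity in this test and lower numbers for higher toxicity in this test. Compound 1 `CN1CCN(CC(=O)Nc2ccc(-c3nc4cc(Cl)c(Cl)cc4[nH]3)cc2)CC1` gives 11000 nM, compound 3 `Oc1ccc(-c2nc3cc(Cl)c(Cl)cc3[nH]2)cc1` gives 12000 nM, and compound 2 `CN1CCN(CC(=O)Nc2ccc(-c3nc4cc(C(F)(F)F)ccc4n3C)cc2)CC1` gives 22000 nM. Compound 2 sits within the usual scatter of both others, its nearest neighbour being compound 3 and the other compound 1, so these three numbers cannot be told apart. Compound 4 `Cn1c(-c2ccc(NC(=O)CN3CCN(c4ccccc4)CC3)cc2)nc2cc(C(F)(F)F)ccc21` has not yet been measured. It differs from compound 2 in one place (phenyl in place of methyl on an amine nitrogen in a ring). Among the compounds with values here, no measured pair shows this same change, so the three values are all there is to build on. The estimated step of a 1.8-fold lower number from compound 2 to compound 4 (0.26 log units; within the scatter) is expected to be small, leaning toward somewhat higher toxicity but not clearly beyond the scatter. Compound 4 is expected to give 12000 nM, with a range from 4000 nM to 36000 nM.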

Compound 4, half-maximal cytotoxic concentration: 1500 nM
For compound 4 the middle estimate is 8.0-fold (0.90 log units) above the measured one, outside the stated range (below it).
By their numbers in this assay, from the lowest: compound 4; then compounds 1, 3 and 2 (each within the scatter of the next).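

In this assay, going from 4-methylpiperazin-1-yl to 4-phenylpiperazin-1-yl gives a 15-fold lower number from compound 2 to compound 4 (1.17 log units; beyond the scatter), a large step that shows this ring nitrogen is sensitive to what it carries. The three earlier compounds lay within the scatter of one another and gave no sign of this. Nothing measured here explains the step.

Going by these compounds, whether it takes an aromatic ring or merely a larger group stays open: a cyclohexyl ring, a benzyl group or a longer alkyl chain on this nitrogen would help separate the two. On these data alone, whether the same change acts alike on the core of compound 1 is also open.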